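This account rests on a few compounds, and the source may have more. Where it says the series, first, only, none or still open, it means among the compounds named here.

Measured compounds:
Compound 1 `CC[C@@H]1C(=O)N(C)c2cnc(-n3ccc4cc(C(N)=O)ccc43)nc2N1C1CCCC1`: in a functional assay on A549 cells (Homo sapiens) for antiproliferative activity, read by CCK-8 assay, with a stated time of 72 h (a lower number here means a stronger inhibitor of growth, a higher number a weaker inhibitor of growth), compound 1 gives 4350 nM.
Compound 2 `CC[C@@H]1C(=O)N(C)c2cnc(-n3ccc4cc(C(=O)NC5CCCC5)ccc43)nc2N1C1CCCC1`: compound 2 gives 670 nM.
Compound 3 `CCC1C(=O)N(C)c2cnc(-n3ccc4cc(C(=O)NC5CCCC5)ccc43)nc2N1c1ccn(C)n1`: compound 3 gives 39500 nM.

Compound 4 `CCC1C(=O)N(C)c2cnc(-n3ccc4cc(C(N)=O)ccc43)nc2N1c1ccn(C)n1` has not been measured. It differs from compound 3 in one place: hydrogen in place of cyclopentyl on an amide-type nitrogen. The same change, at the same kind of place, was made between two measured compounds: hydrogen in place of cyclopentyl on an amide-type nitrogen. That step weakened growth inhibition, the step being a 6.5-fold higher number from compound 2 to compound 1 (0.81 log units; beyond the scatter). The cores of compound 2 and compound 3 are not the same, and the difference between the two cores is not broken down here; what the values show is that compound 3 sits well above compound 2 and also above compound 1, with both gaps beyond the scatter.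

Within the data shown here, since the change from compound 3 to compound 4 is the same as the one from compound 2 to compound 1, a step of similar size and direction is expected, namely a 5.1-fold higher number from compound 3 to compound 4 (0.70 log units; beyond the scatter). Compound 4 is therefore estimated to give 200000 nM, within 60000 nM to 600000 nM, and it is possible that such a weak inhibitor is reported only as a limit.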

Compound 4, concentration for 50% growth inhibition: 39500 nM
Compound 4: the middle estimate sits 5.1-fold (0.70 log units) above what was measured; measured number outside the range, below it.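

In this assay, putting hydrogen in place of cyclopentyl on an amide-type nitrogen in the core of compound 3 gave no change at the digits printed from compound 3 to compound 4 (within the scatter). Set beside the earlier step, this shows that the effect of the change did not carry over from the core of compound 2 to the core of compound 3, so a step measured on one core in this series cannot simply be transferred to the other: the same change on two cores in this assay, a 6.5-fold higher number (0.81 log units; beyond the scatter) from compound 2 to compound 1 and no change at the digits printed (within the scatter) from compound 3 to compound 4, 6.5-fold (0.81 log units) apart, beyond the scatter of two such steps. It does not show which of the differences between the two cores is responsible, and two pairs give no rule for any further core.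

The compounds shown leave open how a methyl, an ethyl or a longer chain on the amide-type nitrogen would behave on each of the two cores. They also leave open whether an amine or a carboxylic acid carried on such a chain would separate the two cores in the same way.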